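The compounds below may be only part of what the source reports. "The series", "measured", "known", "first", "only" and "open" are said of these compounds alone.

Compound 1 `O=c1[nH]c(=O)n([C@H]2C[C@H](O)[C@@H](CO)O2)cc1/C=C/I` — 63900 nM
Compound 2 `Nc1nc(=O)ccn1COCCO` — > 200000 nM

For the measured compounds named here, in an ADME assay on L1210/0 cells (Mus musculus) for cytotoxicity, with a stated time of 48 h (a lower number here means a stronger inhibitor, a higher number a weaker inhibitor), compound 1 gives 63900 nM, the only actual number among the values shown. Compound 2 returns only a limit of the assay, > 200000 nM. That limit is described by the limit of > 200000 nM in this assay, at which 1 of the 2 values shown sits.

Compound 3 `C=CC#Cc1cn([C@H]2C[C@H](O)[C@@H](CO)O2)c(=O)[nH]c1=O` differs from compound 1 in a single place: a group of 4 heavy atoms (4 carbon; no ring) in place of a group of 3 heavy atoms (2 carbon, 1 iodine; no ring), on an aromatic carbon. Going by the values given here, no measured pair in this assay isolates such a change, so the expectation rests on compound 1 alone. The step from compound 1 to compound 3 is expected to be a 2.1-fold lower number from compound 1 to compound 3 (0.33 log units; beyond the scatter), a modest gain barely past the scatter. Compound 3 is therefore estimated at 30000 nM, within 8000 nM to 150000 nM.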

Compound 3, half-maximal inhibitory concentration: > 200000 nM
Compound 3: only a limit was reported; the forecaster's own chance of this, stated with the estimate: 15%; at least 6.6-fold (0.82 log units) between middle value and limit.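

In this assay, swapping the 2-iodoethenyl group on this aromatic carbon for the all-carbon group with a double and a triple bond gives an at least 3.1-fold higher number from compound 1 to compound 3 (0.49 log units; beyond the scatter), so this position does not accept both unsaturated groups alike. Compound 3 gives only a limit, and it joins compound 2 there: the limit of > 200000 nM in this assay, at which 2 of the 3 values shown sit.

Going by these compounds, how far compound 3 lies from compound 1 therefore stays open. The compounds shown also leave open whether a 2-bromoethenyl group, a plain ethynyl group or an amine on this carbon would return a measurable number.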